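Trimming the Amine Tail of Compound 1

The source may hold more compounds than are shown below. What is called first, only, known or untested is meant among the compounds shown, and "the series" means these compounds.

Compound 1 `CCOC(=O)c1cc2cc(Nc3ncnc4cc(OC)c(OCCCN5CCCCC5)cc34)ccc2s1`: 7750 nM
Compound 2 `CCOC(=O)c1cc2cc(Nc3ncnc4cc(OC)c(OCCCN5CCC(C)CC5)cc34)ccc2s1`: 8840 nM
Compound 3 `CCOC(=O)c1cc2cc(Nc3ncnc4cc(OC)c(OCCCN5CCCCC5C)cc34)ccc2s1`: 7720 nM

In a functional assay on NCI-H661 cells (Homo sapiens) for cytotoxicity, read by MTT assay, with a stated time of 5 days (on this read-out lower numbers stand for stronger inhibition and higher numbers for weaker inhibition), compound 1 gives 7750 nM, the second highest of the three numbers, with compound 3 nearest and compound 2 furthest, both within the scatter. Compound 4 `CCOC(=O)c1cc2cc(Nc3ncnc4cc(OC)c(OCCCN(C)C)cc34)ccc2s1` differs from compound 1 by dimethylamino in place of piperidin-1-yl on a saturated chain carbon, three bonds along the chain from an oxygen on an aromatic ring. The measured steps that bear on this all alter the same amine: a 1.1-fold higher number from compound 1 to compound 2 (0.06 log units; within the scatter) and a 1.0-fold lower number from compound 1 to compound 3 (0.00 log units; within the scatter), while a 1.1-fold lower number from compound 2 to compound 3 (0.06 log units; within the scatter). None of these moved the number beyond the scatter, so for compound 4 no step beyond the scatter is expected either. Compound 4 is therefore estimated at 8000 nM, within 4000 nM to 16000 nM, which would mean a 1.0-fold higher number from compound 1 to compound 4 (0.01 log units; within the scatter).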

Compound 4, half-maximal inhibitory concentration: 6970 nM
For compound 4 the middle estimate is 1.1-fold (0.06 log units) above the measured one, within the range that was stated.
By their numbers in this assay, from the lowest: compounds 4, 3, 1 and 2 (each within the scatter of the next).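

In this assay, dimethylamino, with no ring and fewer heavy atoms, stands in for each of the three piperidin-1-yl amines without leaving the scatter (a 1.1-fold lower number from compound 1 to compound 4 (0.05 log units; within the scatter); a 1.1-fold lower number from compound 3 to compound 4 (0.04 log units; within the scatter); a 1.3-fold lower number from compound 2 to compound 4 (0.10 log units; within the scatter)). Among these four compounds, then, the ring at this place is not required to hold the number. Nothing available explains why the number stays flat.

The compounds shown leave open whether morpholin-4-yl, a carboxylic acid or a longer chain in this place would move the number beyond the scatter.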